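The source may hold more compounds than are shown below. What is called first, only, known or untested is meant among the compounds shown, and "the series" means these compounds.

Measured in an ADME assay on Vero cells (Chlorocebus sabaeus) for cytotoxicity, read by MTT assay; on this read-out lower numbers stand for higher toxicity in this test and higher numbers for lower toxicity in this test:
Compound 1 `Cn1nc(C(F)(F)F)cc1C(=O)Nc1ccc(S(=O)(=O)N2CCCCC2)cc1`: > 300000 nM (a limit, not a number)
Compound 2 `Cn1nc(C(F)(F)F)cc1C(=O)Nc1ccc(S(=O)(=O)N2CCCCCCC2)cc1`: 16000 nM
Compound 3 `Cn1nc(C(F)(F)F)cc1C(=O)Nc1ccc(S(=O)(=O)N2CCC(N)CC2)cc1`: > 300000 nM (a limit, not a number)

Compound 3 has only a limit, > 300000 nM, and no exact number. It shares that position with one other compound, as the set shows (the limit of > 300000 nM in this assay, at which 2 of the 3 values shown sit).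

Compound 4 `Cn1nc(C(F)(F)F)cc1C(=O)Nc1ccc(S(=O)(=O)N2CCCC(C(=O)O)C2)cc1` keeps the shared core and changes one group on a sulfonyl sulfur, with 3-carboxypiperidin-1-yl in place of 4-aminopiperidin-1-yl (3-carboxypiperidin-1-yl in place of 4-aminopiperidin-1-yl on a sulfonyl sulfur). The six-membered non-aromatic ring stays.

Two kinds of measured step bear on this. Adding amino to the ring gave a step that the two limits leave unreadable from compound 1 to compound 3, so that change shows no measurable size. The large changes came only with the eight-membered ring of compound 2, as in an at least 18-fold lower number from compound 1 to compound 2 (1.27 log units; beyond the scatter) and in the return an at least 18-fold higher number from compound 2 to compound 3 (1.27 log units; beyond the scatter). Compound 4 has no such ring, so it is expected to stay with the six-membered compounds, and no step beyond the scatter is expected in this assay. If a drop does appear, it can only be read as a lower number, and the assay may well report a limit again.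

The expected change is a number no higher from compound 3 to compound 4 (the limit leaves the size open). For compound 4 the estimated value is 300000 nM, with an expected range from 100000 nM to 600000 nM.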

Compound 4, half-maximal cytotoxic concentration: > 300000 nM
Compound 4: no number, only a limit; the forecaster's own chance of this, stated with the estimate: 70%; the middle value lies on the limit itself.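

In this assay compound 4 gives > 300000 nM, a limit and not a number, so a carboxy group on the six-membered ring ends in the same place as the amino group of compound 3 and the unsubstituted ring of compound 1: the limit of > 300000 nM in this assay, at which 3 of the 4 values shown sit.

Among the compounds shown here, the contrast with the eight-membered ring of the only compound with an exact number now holds for a second substituted six-membered ring, as an at least 18-fold higher number from compound 2 to compound 4 (1.27 log units; beyond the scatter) shows. The steps among compound 1, compound 3 and compound 4 cannot be read, since each one joins two limits, so this result gives no size for the change from 4-aminopiperidin-1-yl to 3-carboxypiperidin-1-yl.

As far as these compounds go, the real values of these three compounds stay unknown, and so does any order among them. From the compounds shown here alone, it also remains open whether a methyl ester in place of the carboxy group, or a longer chain on the six-membered ring, would give an exact number in this assay.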